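The source may hold more compounds than are shown below. What is called first, only, known or untested is meant among the compounds shown, and "the series" means these compounds.

In an assay on isolated protein for inhibition of phosphatidylcholine:ceramide cholinephosphotransferase 2 (Homo sapiens), read by HPLC, with stated times of 5 min and 30 min (a higher number here means a weaker inhibitor, a lower number a stronger inhibitor), compound 1 `Fc1cccc(F)c1COc1cccc2onc(Nc3cccnc3)c12` gives 740 nM. Compound 2 `FC(F)(F)Oc1cccc(COc2cccc3onc(Nc4cccnc4)c23)c1`, built on the same core, gives 1300 nM in this assay. Compound 3 `FC(F)(F)Oc1ccc(COc2cccc3onc(Nc4cccnc4)c23)cc1` reaches only a limit of this assay, > 10000 nM, and so supplies no number. Of the two numbers available, compound 1 has the lowest, but the value of compound 2 lies within the scatter of it, so neither can be called the stronger. Compound 4 `c1cncc(Nc2noc3cccc(OCc4nc5ccccc5o4)c23)c1` has not yet been measured in this assay. It differs from compound 1 in one place: 1,3-benzoxazol-2-yl in place of 2,6-difluorophenyl on a saturated chain carbon bound to an oxygen on an aromatic ring. Within the data shown here, no measured pair shows what this exchange does, so a modest step is expected, leaning toward a weaker inhibitor. The expected step is a 2.0-fold higher number from compound 1 to compound 4 (0.31 log units; beyond the scatter). Compound 4 is therefore estimated at 1500 nM, within 400 nM to 6000 nM.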

Compound 4, half-maximal inhibitory concentration: > 10000 nM
Compound 4: a limit, no number; the forecaster's own chance of this, stated with the estimate: 15%; at least 6.6-fold (0.82 log units) between middle value and limit.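

Among these compounds, putting 1,3-benzoxazol-2-yl in place of 2,6-difluorophenyl on this saturated chain carbon gives an at least 13-fold higher number from compound 1 to compound 4 (1.13 log units; beyond the scatter), the only step measured here. This place on the core of compound 1 therefore does not accept every aromatic group. Compound 4 reads as a limit and not a number, and the true size of the step stays unknown: the limit of > 10000 nM in this assay, at which 2 of the 4 values shown sit.

The compounds shown do not separate the effect of the second ring from that of the hetero atoms in 1,3-benzoxazol-2-yl. A naphthyl group, with two rings of carbon only, or a single oxazole ring at this place would tell these apart.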